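A few compounds are considered here, and "the series" means these few. Any claim that something is new, unique, unknown or untested is made for them only; others in the source may bear on it.

Measured compounds: compound 2 `c1ccc2c(c1)CCC2NCC1CCN(CCCc2c[nH]c3ccc(-n4cnnc4)cc23)CC1`, 1.1 nM in an assay on CHO cells for displacement of a labelled ligand from 5-hydroxytryptamine receptor 1D (Homo sapiens); on this read-out lower numbers stand for stronger inhibition and higher numbers for weaker inhibition; compound 1 `CN(Cc1ccco1)C1CCN(CCCc2c[nH]c3ccc(-n4cnnc4)cc23)CC1`, 9.3 nM.

Going by the values given here, on the numbers so far, compound 2 has the lowest value of the two; its nearest neighbour is compound 1, and the step of an 8.5-fold lower number from compound 1 to compound 2 (0.93 log units; beyond the scatter) separates them beyond the scatter. The unmeasured compound 3 `c1cncc(CNC2CCN(CCCc3c[nH]c4ccc(-n5cnnc5)cc34)CC2)c1` is obtained from compound 2 by a single change, (((pyridin-3-yl)methyl)amino in place of ((2,3-dihydro-1H-inden-1-yl)amino)methyl on a saturated ring carbon). Among the compounds with values here, the one measured step that bears on this is an 8.5-fold lower number from compound 1 to compound 2 (0.93 log units; beyond the scatter), where a small aromatic-methyl amine on the same saturated ring carbon gave way to the indanylamino-methyl group and the number fell. Compound 3 returns to a small aromatic-methyl amine on that carbon, so the step is expected to run the other way, giving back a good part of that loss: a 5.5-fold higher number from compound 2 to compound 3 (0.74 log units; beyond the scatter). Compound 3 is therefore estimated at 6 nM, within a range of 2 nM to 20 nM.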

Compound 3, half-maximal inhibitory concentration: 35 nM
Compound 3: the middle estimate sits 5.8-fold (0.77 log units) below what was measured, outside the stated range (above it).
By their numbers in this assay, from the lowest: compound 2; then compound 1; then compound 3.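

In this assay, ((pyridin-3-yl)methyl)amino in place of ((2,3-dihydro-1H-inden-1-yl)amino)methyl gives a 32-fold higher number from compound 2 to compound 3 (1.50 log units; beyond the scatter) as a large step, so this position does not tolerate the exchange without a clear cost. Replacing ((furan-2-yl)methyl)(methyl)amino with the same group also gives a 3.8-fold higher number from compound 1 to compound 3 (0.58 log units; beyond the scatter) and is a modest step, which shows that the two smaller aromatic-methyl amines are not interchangeable on this saturated ring carbon. Nothing shown here explains either step.

Each step changes several features of the group at once, so the compounds shown cannot assign the loss to the aromatic ring, the methyl on the amine or the way the group is attached. A phenylmethylamino group, or a 2,3-dihydro-1H-inden-1-ylamino group attached directly through its amine to the ring carbon, would separate these features.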